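Cytotoxicity After Swapping an Aminophenyl for a Difluorophenyl

The source may hold more compounds than are shown below. What is called first, only, known or untested is meant among the compounds shown, and "the series" means these compounds.

Compound 1 `Cc1c(CNCCN2CCN(C)CC2)c(-c2ccccc2)nn1-c1ccc(F)cc1`: > 20000 nM
Compound 2 `Cc1ccccc1-c1nn(-c2ccc(N)cc2)cc1CNCCN1CCN(C)CC1`: > 20000 nM
Compound 3 `CN1CCN(CCCNCc2cn(-c3ccc([N+](=O)[O-])cc3)nc2-c2ccc(OC(F)(F)F)cc2)CC1`: 1600 nM

All three compounds were examined in an ADME assay on Huh-7 cells (Homo sapiens) for cytotoxicity; on this read-out lower numbers stand for higher toxicity in this test and higher numbers for lower toxicity in this test. For compound 2 the read-out is a limit of the test rather than a number, > 20000 nM. Compound 1 also comes out only as a limit, > 20000 nM. Going by the values given here, compound 3 is the one compound with a numerical value, 1600 nM. Compound 2 therefore stands at the upper edge of what this assay reports, and it is not alone there, as the limit of > 20000 nM in this assay, at which 2 of the 3 values shown sit, shows.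

Compound 4 `Cc1ccccc1-c1nn(-c2ccc(F)c(F)c2)cc1CNCCN1CCN(C)CC1` is the next compound in this series. It differs from compound 2 in one place: 3,4-difluorophenyl in place of 4-aminophenyl on an aromatic nitrogen. Among the compounds with values here, no pair of measured compounds differs only in this way, so the size of the step cannot be read from the data. Compound 1, which also carries a fluorine-bearing phenyl on that aromatic nitrogen, sits at the limit > 20000 nM. On that basis the expected step in this assay is a number no higher from compound 2 to compound 4 (the limit leaves the size open), nothing beyond the usual scatter. Compound 4 is estimated to give 20000 nM, with a likely range from 8000 nM to 40000 nM, and most probably again only a limit.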

Compound 4, half-maximal cytotoxic concentration: > 20000 nM
Compound 4 gave a limit, no number; the forecaster's own chance of this, stated with the estimate: 65%; the middle value lies on the limit itself.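

In this assay compound 4 gives > 20000 nM, which is a limit and not a number. Compound 2 also stands at a limit, so no step can be read between compound 2 and compound 4, and both share the same edge of the test: the limit of > 20000 nM in this assay, at which 3 of the 4 values shown sit. The compounds shown leave open whether 3,4-difluorophenyl in place of 4-aminophenyl alters the read-out at all, and in which direction.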